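The source may hold more compounds than are shown below. What is called first, only, known or untested is meant among the compounds shown, and "the series" means these compounds.

Measured so far:
compound 1, `CN1CCN(CCCCCn2c3c(c4ccccc42)C(=O)c2c[n+]([O-])c4ccccc4c2C3=O)CC1` — 1260 nM in a functional assay on MCF7 cells (Homo sapiens) for cytotoxicity, read by MTT assay, with a stated time of 72 h; a higher number here means a weaker inhibitor, a lower number a stronger inhibitor
compound 2, `O=C1c2c[n+]([O-])c3ccccc3c2C(=O)c2c1c1ccccc1n2Cc1cn([C@H]2C[C@H](O)[C@@H](CO)O2)nn1` — 530 nM in this assay

Compound 1 gives the highest of the two numbers in this assay; compound 2 gives a lower number, and the gap between the two lies beyond the scatter of repeated measurements. Going by the values given here, no step between compound 1 and compound 2 is counted here, since they differ in more than one place, so only the two values themselves can be compared.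

Compound 3, `CN1CCN(CCCCn2c3c(c4ccccc42)C(=O)c2c[n+]([O-])c4ccccc4c2C3=O)CC1`, is not yet measured. It differs from compound 1 in one place: 4-methylpiperazin-1-yl in place of (4-methylpiperazin-1-yl)methyl on a saturated chain carbon, four bonds along the chain from an aromatic nitrogen. Cut one bond further out, the same difference reads as 4-(4-methylpiperazin-1-yl)butyl to 3-(4-methylpiperazin-1-yl)propyl.

Among the compounds with values here, no comparable step is available to set a size for this change. Shortening a saturated chain by one link is expected to give a step from compound 1 to compound 3 of a 1.1-fold lower number from compound 1 to compound 3 (0.02 log units; within the scatter), that is, none beyond the scatter, in either direction. For compound 3 the expected value in this assay is 1200 nM, with a range of 450 nM to 3200 nM, because compound 1 gives 1260 nM and the change is small.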

Compound 3, half-maximal inhibitory concentration: 100 nM
Compound 3: middle estimate off by 12-fold (1.08 log units), on the high side, and the stated range ends above it.
By their numbers in this assay, from the lowest: compound 3; then compound 2; then compound 1.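

In this assay, chain length proves to be a sensitive variable at this position: shortening the saturated chain that carries the 4-methylpiperazin-1-yl group by one link gives a 13-fold lower number from compound 1 to compound 3 (1.10 log units; beyond the scatter), although the terminal ring and the shared core stay the same. Going by these compounds alone, this is the first single-place step, and it sets a size for a change that the two earlier values could not address, as compound 1 and compound 2 differ in more than one place. Nothing available accounts for the size of this step, so it stands as an observation without an explanation.

From the compounds shown here alone, two chain lengths give a difference but not a trend, so it remains open whether 2-(4-methylpiperazin-1-yl)ethyl, a shorter chain, would continue the direction of this step or reverse it, and whether a chain longer than that of compound 1 would follow the same direction. Going by these compounds, it is also open whether the effect of chain length depends on the terminal 4-methylpiperazin-1-yl group or would persist with another end group on the same chain, such as a morpholine or a dimethylamine.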